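Adding a methyl to the amino group of compound 2

The source may hold more compounds than are shown below. What is called first, only, known or untested is meant among the compounds shown, and "the series" means these compounds.

In an assay on isolated protein for inhibition of activin receptor type-2A (Homo sapiens), read by 33P incorporation, with a stated time of 20 min, in the presence of a further agent that is not named here (a lower number here means a stronger inhibitor, a higher number a weaker inhibitor), compound 1 `COc1cc(-c2cnn3cc(OC)c(C4CCCC4)nc23)ccn1` gives 2900 nM, while compound 2 `CNc1nc2c(-c3ccnc(OC)c3)cnn2cc1OC` gives 310 nM, the lowest of the two numbers measured. For the measured compounds named here, that difference is the only measured step, a 9.4-fold lower number from compound 1 to compound 2 (0.97 log units; beyond the scatter), which describes a change at a different part of the molecule. Compound 3 `COc1cc(-c2cnn3cc(OC)c(N(C)C)nc23)ccn1` differs from compound 2 by methyl in place of hydrogen on a nitrogen on an aromatic ring. Going by the values given here, no measured step covers this change, so the expectation is a small shift, at most near the edge of the scatter, expected as a 1.6-fold higher number from compound 2 to compound 3 (0.21 log units; within the scatter). Compound 3 is therefore estimated at 500 nM, with a range from 150 nM to 1600 nM.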

Compound 3, half-maximal inhibitory concentration: 3000 nM
For compound 3 the middle estimate is 6.0-fold (0.78 log units) below the measured one; measured number outside the range, above it.
By their numbers in this assay, from the lowest: compound 2; then compounds 1 and 3 (each within the scatter of the next).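

In this assay, the hydrogen on this nitrogen turns out to matter: replacing it with a single methyl, which turns methylamino into dimethylamino, gives (a 9.7-fold higher number from compound 2 to compound 3 (0.99 log units; beyond the scatter)). Dimethylamino in place of cyclopentyl gives (a 1.0-fold higher number from compound 1 to compound 3 (0.01 log units; within the scatter)), which lies within the scatter, so among these three groups only methylamino brings the lower number. Nothing available here explains this loss. From the compounds shown here alone, whether a plain amine or ethylamino at this position would behave like methylamino or like dimethylamino remains open.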